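The source may report more compounds than this note shows. Statements on the series, on what has been measured and on what is new or still open speak of the compounds shown alone.

Measured so far:
compound 1, `Oc1ccc(-c2cc(-c3cccc(O)c3)nc(-c3cccc(O)c3)c2)cc1`, 730 nM in an ADME assay on HEK293 cells (Homo sapiens) for cytotoxicity, read by CCK-8 assay, with a stated time of 4 days; on this read-out lower numbers stand for stronger inhibition and higher numbers for weaker inhibition;
compound 2, `Oc1cccc(-c2cc(-c3ccccc3O)nc(-c3ccccc3O)c2)c1`, 80 nM in this assay.

Of these two, compound 2 gives the lower number, so it is the stronger inhibitor of cell growth; compound 1 gives a clearly higher number. Compound 3, `Oc1cccc(-c2cc(-c3cccc(O)c3)nc(-c3ccccc3O)c2)c1`, has not been measured. Relative to compound 2 the change is 3-hydroxyphenyl in place of 2-hydroxyphenyl on an aromatic carbon. Compound 3 thus sits between compound 2 and compound 1 in how many of each hydroxyphenyl group it carries, so a step toward the weaker side is expected from compound 2 to compound 3, of about a 3.0-fold higher number from compound 2 to compound 3 (0.48 log units; beyond the scatter) in this assay, beyond the scatter. Compound 3 is expected to give roughly 240 nM, likely within 100 nM to 600 nM.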

Compound 3, half-maximal inhibitory concentration: > 50000 nM
Compound 3 gave a limit, no number (the forecaster's own chance of this, stated with the estimate: 3%); middle value at least 200-fold (2.31 log units) away from the limit.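

The exact placement of the hydroxyl on this one ring, on an aromatic carbon next to the ring nitrogen, matters greatly. With the same atoms, 3-hydroxyphenyl in place of 2-hydroxyphenyl gives an at least 620-fold higher number from compound 2 to compound 3 (2.79 log units; beyond the scatter) in this assay, so a single change here can remove nearly all of the effect on cell growth. Compound 3 is recorded only as a limit, not as a number: the limit of > 50000 nM in this assay, at which 1 of the 3 values shown sits.

Going by these compounds, it remains open whether an amine or a methoxy group at this position would keep the effect seen with compound 2. On these data alone, whether the other 2-hydroxyphenyl group of compound 2 is equally sensitive also remains open.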